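Trading 4-Methoxyphenyl for 2,3-Dichlorophenyl

A few compounds are considered here, and "the series" means these few. Any claim that something is new, unique, unknown or untested is made for them only; others in the source may bear on it.

In a functional assay on HT-1080 cells (Homo sapiens) for cytotoxicity, read by MTT assay, with a stated time of 72 h (a lower number here means a stronger inhibitor, a higher number a weaker inhibitor), three compounds built on a shared core have been measured so far. Compound 1 `COc1cccc(/C=C2\CCC/C(=C\c3ccccc3Cl)C2=O)c1OC` gives 11700 nM, compound 2 `COc1cccc(/C=C2\CCC/C(=C\c3cccc(Br)c3)C2=O)c1OC` gives 12200 nM, and compound 3 `COc1ccc(/C=C2\CCC/C(=C\c3cccc(OC)c3OC)C2=O)cc1` gives 16300 nM. Compound 3 therefore stands level with the other two, since no gap among these numbers exceeds the ordinary scatter of repeated measurements.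

Compound 4 `COc1cccc(/C=C2\CCC/C(=C\c3cccc(Cl)c3Cl)C2=O)c1OC` carries 2,3-dichlorophenyl in place of the 4-methoxyphenyl of compound 3, on a double-bonded chain carbon bound to a double-bonded ring carbon: 2,3-dichlorophenyl in place of 4-methoxyphenyl on a double-bonded chain carbon bound to a double-bonded ring carbon.

Within the data shown here, two measured steps bear most directly on this change, as each puts 4-methoxyphenyl in place of a phenyl group carrying a halogen. With 2-chlorophenyl as the starting group, the step is a 1.4-fold higher number from compound 1 to compound 3 (0.14 log units; within the scatter). With 3-bromophenyl as the starting group, it is a 1.3-fold higher number from compound 2 to compound 3 (0.13 log units; within the scatter). Exchanging those two starting groups gives a 1.0-fold higher number from compound 1 to compound 2 (0.02 log units; within the scatter). None of these steps leaves the scatter, although none tests 2,3-dichlorophenyl itself, so no step beyond the scatter is expected in this assay.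

The expected change is a 1.4-fold lower number from compound 3 to compound 4 (0.13 log units; within the scatter). For compound 4 the estimated value is 12000 nM, with an expected range from 5500 nM to 26000 nM.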

Compound 4, half-maximal inhibitory concentration: 19300 nM
Estimate against measurement, compound 4: 1.6-fold (0.21 log units) below; low and high end bracket the measured number.
By their numbers in this assay, from the lowest: compounds 1, 2, 3 and 4 (each within the scatter of the next).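

In this assay, this position on the double-bonded chain carbon now accepts 2,3-dichlorophenyl in place of 4-methoxyphenyl with no step beyond the scatter (a 1.2-fold higher number from compound 3 to compound 4 (0.07 log units; within the scatter)), so an oxygen-bearing group and a group bearing only halogens cannot be told apart here. The earlier compounds shown here tested only a chloro or a bromo alone on this phenyl ring, whereas compound 4 adds a further chloro in place of hydrogen on an aromatic carbon (a 1.6-fold higher number from compound 1 to compound 4 (0.22 log units; within the scatter)) and also stands within the scatter when 2,3-dichlorophenyl replaces 3-bromophenyl (a 1.6-fold higher number from compound 2 to compound 4 (0.20 log units; within the scatter)), so all four groups remain level at this position. No measurement shown speaks to why these changes leave the number within the scatter.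

Whether any group at this position can move the number beyond the scatter remains open, as every step among these four compounds stays within it. An amine or a carboxylic acid on this phenyl ring would test that question with groups quite unlike the methoxy, chloro and bromo seen so far.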